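Moving the chlorine around a thiophene in a paw edema series

The source may report more compounds than this note shows. Statements on the series, on what has been measured and on what is new or still open speak of the compounds shown alone.

In a functional assay on the whole organism (strain Wistar) for inhibition, with Rattus norvegicus as the target, read by paw edema, with stated times of 30 min and 0.5 h, at a dose of 20 mg/kg (a lower number here means less inhibition, a higher number more inhibition at the dose given (going by the name of the read-out)), the three measured compounds gave these numbers:
compound 1 `CCOC(=O)C1=C(C)NC(C)=C(C(=O)OCC)C1c1ccc(OCC(=O)Nc2ccc(C)cc2)cc1`: 43.9%
compound 2 `CCOC(=O)C1=C(C)NC(C)=C(C(=O)OCC)C1c1ccc(OCC(=O)NNC(=O)c2ccc(C)cc2)cc1`: 16.7%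
compound 3 `CCOC(=O)C1=C(C)NC(C)=C(C(=O)OCC)C1c1ccc(OCC(=O)NNC(=O)c2sccc2Cl)cc1`: 10.6%

Compound 3 gives the lowest number of the three, although compound 2 lies within the scatter of it; the gap to compound 1 is clear, a number 33.3 percentage points lower from compound 1 to compound 3 (beyond the scatter). Compound 4 `CCOC(=O)C1=C(C)NC(C)=C(C(=O)OCC)C1c1ccc(OCC(=O)NNC(=O)c2ccsc2Cl)cc1` differs from compound 3 in one place: 2-chlorothiophen-3-yl in place of 3-chlorothiophen-2-yl on a carbonyl carbon. Going by the values given here, the only measured step that also changes the group on that carbonyl carbon is a number 6.1 percentage points lower from compound 2 to compound 3 (within the scatter), which stayed within the scatter; the other two steps alter a different part of the molecule. So no step beyond the scatter is expected in this assay, a number 1.4 percentage points higher from compound 3 to compound 4 (within the scatter). Compound 4 is therefore estimated at 12%, in a range from 2% to 25%.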

Compound 4, a percentage reported as inhibition, in the whole organism at one dose (the size of the read-out at that dose, not a potency): 12.9%
The estimate for compound 4 lay 0.9 percentage points below the measured number, within the range that was stated.
By their numbers in this assay, from the lowest: compounds 3, 4 and 2 (each within the scatter of the next); then compound 1.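

In this assay, placing 2-chlorothiophen-3-yl in place of 3-chlorothiophen-2-yl on the carbonyl carbon gives a number 2.3 percentage points higher from compound 3 to compound 4 (within the scatter), so rearranging the same atoms at this position produces no real change. The new thiophene also stays level with 4-methylphenyl on that carbonyl carbon, with a number 3.8 percentage points lower from compound 2 to compound 4 (within the scatter), whereas the larger change on the amide-type nitrogen still leaves a clear gap, with a number 31 percentage points lower from compound 1 to compound 4 (beyond the scatter). Nothing available offers a reason for these results. Going by these compounds, it remains open whether a thiophene without chlorine, or one carrying a methyl group or a carboxylic acid instead, would also leave the number unchanged.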